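Chloro in place of cyano on compound 1

A few compounds are considered here, and "the series" means these few. Any claim that something is new, unique, unknown or untested is made for them only; others in the source may bear on it.

In an ADME assay (liver) for metabolic stability, with Liver microsome (Homo sapiens) as the target, using microsomes (a higher number here means faster removal of the compound, a lower number slower removal), compound 1 (`N#Cc1c(-c2ccc(OCC3CCOC3)c(OC(F)(F)F)c2)nc(N)[nH]c1=O`) gives 21 mL.min-1.g-1. Compound 2 (`CC(C)COc1ccc(-c2cc(O)nc(N)n2)cc1`) gives 42 mL.min-1.g-1. Within the data shown here, these two values lie within the scatter of each other, so neither can be set apart from the other, and together they mark only the general level of the series so far.

The next compound to be read is compound 3 (`Nc1nc(-c2ccc(OCC3CCOC3)c(OC(F)(F)F)c2)c(Cl)c(=O)[nH]1`), which carries chloro in place of cyano on an aromatic carbon. Among the measured compounds shown here, no measured pair shows this change, so the expectation rests on judgement and carries a wide range. A small rise is expected, a 1.4-fold higher number from compound 1 to compound 3 (0.15 log units; within the scatter), and it would stay within the scatter of this assay. The direction is tentative. Compound 3 is estimated at 30 mL.min-1.g-1, with an expected range of 14 mL.min-1.g-1 to 65 mL.min-1.g-1.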

Compound 3, intrinsic clearance in microsomes in the Liver microsome assay: 18 mL.min-1.g-1
Estimate against measurement, compound 3: 1.7-fold (0.22 log units) above; low and high end bracket the measured number.
By their numbers in the Liver microsome assay, from the lowest: compounds 3, 1 and 2 (each within the scatter of the next, the first and the last beyond it).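

Among these compounds, in the Liver microsome assay compound 1 gives 21 mL.min-1.g-1 and compound 3 gives 18 mL.min-1.g-1, so chloro in place of cyano on the aromatic carbon para to the amino group gives a 1.2-fold lower number from compound 1 to compound 3 (0.07 log units; within the scatter), the first reading of a single change at this position, and the two groups cannot be told apart here. In a physicochemical assay for solubility, in phosphate buffer, at pH 7.4 (a lower number here means a less soluble compound, a higher number a more soluble compound), compound 1 gives 86000 nM and compound 3 gives 45000 nM, so the same change gives a 1.9-fold lower number from compound 1 to compound 3 (0.28 log units; within the scatter), and this read-out does not separate chloro from cyano at this position either. Nothing available explains either reading.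

Open, as far as these compounds go, is whether another group on this aromatic carbon, such as a methyl, an amine or a carboxylic acid, would give a step beyond the scatter in either read-out. Also open, from the compounds shown here alone, is whether chloro in place of cyano reads the same way when the chain on the outer ring is a longer alkyl ether.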